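The source may report more compounds than this note shows. Statements on the series, on what has been measured and on what is new or still open speak of the compounds shown alone.

Of the compounds shown here, three built on a shared core have been tested for their inhibition of radioligand binding at the serotonin receptor at a single concentration. Compound 1 `CC1CN(CCn2ccc3ccc(Br)cc32)CCN1` gives 52% in an assay on HEK293 cells for binding affinity to 5-hydroxytryptamine receptor 7 (Homo sapiens), read by radioligand binding, tested at 1 uM; a higher number here means more inhibition at the concentration tested (going by the name of the read-out), a lower number less inhibition. Compound 2 `CN1CCCN(CCn2ccc3cccc(Br)c32)CC1` gives 18% in this assay. Compound 3 `CN1CCCN(CCn2ccc3ccc(Cl)cc32)CC1` gives 85% in this assay, the highest of the three numbers: its gap to compound 1 and its gap to compound 2 both lie beyond the scatter of repeated measurements. Among the measured compounds shown here, no pair of these three differs in only one place, so nothing more than the bare numbers can be read from them.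

Compound 4 `CN1CCCN(CCn2ccc3ccc(-c4ccsc4)cc32)CC1` has not yet been measured. Relative to compound 3 it shows one change: thiophen-3-yl in place of chloro on an aromatic carbon. For the measured compounds named here, with no comparable step among the measured compounds, the expectation rests on compound 3 alone. A step downward from compound 3 to compound 4 of moderate size, a number 20 percentage points lower from compound 3 to compound 4 (beyond the scatter), is expected. Compound 4 is therefore estimated to reach 65% in this assay, within a range from 30% to 90%.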

Compound 4, a percentage reported as inhibition, at one concentration (the size of the read-out at that concentration, not a potency): 68%
Compound 4: middle estimate off by 3 percentage points, on the low side, within the range that was stated.
By their numbers in this assay, from the lowest: compound 2; then compound 1; then compound 4; then compound 3.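

Thiophen-3-yl in place of chloro, on the aromatic carbon para to a fused ring and meta to a fused ring, gives the first comparison in which only one place differs, and in this assay it brings a number 17 percentage points lower from compound 3 to compound 4 (beyond the scatter). The larger group, with its five-membered aromatic ring, thus lowers the inhibition at this position, yet compound 4 still gives 68% at the single concentration tested, so the read-out is reduced but not lost. Nothing available bears on the reason for this step.

Going by these compounds, it remains open whether another group on this carbon, such as phenyl, furan-3-yl or a primary amine, would stand nearer to chloro or to thiophen-3-yl. The compounds shown also cannot tell whether the same change would give a step of similar size with the amine ring of compound 1.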